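Nitro for methyl on the aryl ring of compound 2

The source may report more compounds than this note shows. Statements on the series, on what has been measured and on what is new or still open speak of the compounds shown alone.

Two compounds of this series have numbers in a functional assay on HeLa cells (Homo sapiens) for cytotoxicity, read by sulforhodamine B assay, with a stated time of 48 h; a lower number here means a stronger inhibitor, a higher number a weaker inhibitor. Compound 1 `CC1=C(/C=C/C(=O)/C=C/c2ccccc2)C(C)(C)CCC1` gives 70200 nM. Compound 2 `CC1=C(/C=C/C(=O)/C=C/c2ccc(C)cc2)C(C)(C)CCC1`, which carries a methyl on the aromatic ring, gives 20400 nM. Going by the values given here, the only step between compounds that differ in one place is a 3.4-fold lower number from compound 1 to compound 2 (0.54 log units; beyond the scatter). Compound 2 therefore holds the lowest of the two numbers, and its nearest neighbour is compound 1, whose number is higher by a step beyond the scatter.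

Compound 3 `CC1=C(/C=C/C(=O)/C=C/c2ccc([N+](=O)[O-])cc2)C(C)(C)CCC1` is not yet measured in this assay. It differs from compound 2 by nitro in place of methyl on an aromatic carbon. Among the compounds with values here, no measured step exchanges a methyl for a nitro or introduces a nitro anywhere; the single step, hydrogen to methyl from compound 1 to compound 2, concerns the same aromatic carbon but gives no guidance on a nitro there. With nothing to lean on, the change is expected to leave the number close to that of compound 2, as a step of a 1.2-fold higher number from compound 2 to compound 3 (0.09 log units; within the scatter), with no direction claimed beyond the scatter. Compound 3 is accordingly estimated at 25000 nM, within a range from 8000 nM to 80000 nM.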

Compound 3, half-maximal inhibitory concentration: 28700 nM
The estimate for compound 3 lay 1.1-fold (0.06 log units) below the measured number; the measured number falls inside the stated range.
By their numbers in this assay, from the lowest: compounds 2 and 3 (each within the scatter of the next); then compound 1.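

In this assay, nitro in place of methyl on this aromatic carbon, para to a large group, gives a step within the scatter (a 1.4-fold higher number from compound 2 to compound 3 (0.15 log units; within the scatter)), so at this position the data do not separate two groups that differ in heavy atoms and in hydrogen-bond acceptors. Nitro in place of hydrogen on the same carbon gives a modest step beyond the scatter (a 2.4-fold lower number from compound 1 to compound 3 (0.39 log units; beyond the scatter)), and methyl in place of hydrogen does the same (a 3.4-fold lower number from compound 1 to compound 2 (0.54 log units; beyond the scatter)), so the lower number is no longer tied to methyl alone: both groups shown at this carbon stand below hydrogen, and no compound shown goes against this. No measurement on hand explains why these two different groups give numbers within the scatter of each other, so the result stays an observation on three compounds without a stated cause.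

As far as these compounds go, whether an amine, a carboxylic acid, a halogen such as chlorine or a longer alkyl chain on this carbon would stay with compound 2 and compound 3 or move away from them remains open. Also open, from the compounds shown here alone, is whether methyl or nitro would give similar steps on another carbon of the aromatic ring, or in any other cell line.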